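Swapping Bromine for a Six-Membered Oxygen Ring

A few compounds are considered here, and "the series" means these few. Any claim that something is new, unique, unknown or untested is made for them only; others in the source may bear on it.

The three compounds measured so far were tested in a functional assay on OVCAR-8 cells (Homo sapiens) for antiproliferative activity, read by MTT assay, with a stated time of 72 h; on this read-out higher numbers stand for weaker inhibition and lower numbers for stronger inhibition:

compound 1 `O=C(Nc1ccccn1)c1cc(=O)[nH]c2cc(Br)ccc12` — > 20000 nM, a limit of the assay, not a number
compound 2 `O=C(Nc1cccc(F)c1)c1cc(=O)[nH]c2cc(Br)ccc12` — 5800 nM
compound 3 `O=C(Nc1cccc(F)c1)c1cc(=O)[nH]c2cc(-c3ccsc3)ccc12` — 13400 nM

Among these, compound 2 has the lowest of the two actual numbers; its nearest neighbour is compound 3, and a 2.3-fold higher number from compound 2 to compound 3 (0.36 log units; beyond the scatter). The other change in this set, an at least 3.4-fold lower number from compound 1 to compound 2 (0.53 log units; beyond the scatter), concerns the amide side of the shared core and rests on the limit (the limit of > 20000 nM in this assay, at which 1 of the 3 values shown sits), so it says nothing about the aromatic carbon that bears the bromine.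

Compound 4 `O=C(Nc1cccc(F)c1)c1cc(=O)[nH]c2cc(C3=CCOCC3)ccc12` is built from compound 2 by a group of 6 heavy atoms (5 carbon, 1 oxygen; one six-membered non-aromatic ring with 1 hetero atom) in place of one bromine atom, on an aromatic carbon. Among the measured compounds shown here, the only measured step touching that same position is the one from compound 2 to compound 3, where an aromatic ring entered in place of bromine and the number rose modestly. The incoming ring here is non-aromatic and carries an oxygen, so the cases are not identical, yet a similar modest weakening is the most reasonable expectation, with a fair chance the value reaches the assay limit.

Compound 4 is therefore expected to give 10000 nM in this assay, within 4000 nM to 25000 nM, meaning an estimated 1.7-fold higher number from compound 2 to compound 4 (0.24 log units; within the scatter).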

Compound 4, half-maximal inhibitory concentration: 21800 nM
The estimate for compound 4 lay 2.2-fold (0.34 log units) below the measured number; the range from low to high includes it.
By their numbers in this assay, from the lowest: compound 2; then compounds 3 and 4 (each within the scatter of the next).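

In this assay, bromine at this aromatic carbon has now given way to two different rings, and each swap raises the number beyond the scatter: the thiophen-3-yl ring gives a 2.3-fold higher number from compound 2 to compound 3 (0.36 log units; beyond the scatter) and the six-membered oxygen ring gives a 3.8-fold higher number from compound 2 to compound 4 (0.58 log units; beyond the scatter) in the new step. Exchanging one ring for the other gives a 1.6-fold higher number from compound 3 to compound 4 (0.21 log units; within the scatter) and so shows no readable difference between them, even though one is aromatic with sulfur and the other is non-aromatic with oxygen and a double bond. Among these compounds, then, the loss appears with both incoming rings and is not tied to one kind of ring, but nothing measured here explains why either ring falls short of bromine.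

The compounds shown leave open whether a much smaller group on this carbon, such as methyl, methoxy or an amine, would match or improve on bromine, and whether a fully saturated oxygen ring would behave like the one with the double bond. From the compounds shown here alone, it also remains open whether the same order would hold with a group other than 3-fluorophenyl on the amide nitrogen.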